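Anilinoquinazoline series: cytotoxicity at the assay limit

The source may hold more compounds than are shown below. What is called first, only, known or untested is meant among the compounds shown, and "the series" means these compounds.

The series shares one core carrying an arylamino group on the aromatic nitrogen. Compound 1 `Fc1cccc(-c2nc(Nc3ccccc3)c3ccccc3n2)c1` is the simplest member. In a functional assay on HL-60 cells (Homo sapiens) for cytotoxicity, read by MTT assay, with a stated time of 48 h (a lower number here means a stronger inhibitor, a higher number a weaker inhibitor), compound 1 gives only a limit, > 50000 nM. Compound 2 `COc1ccccc1Nc1nc(-c2cccc(F)c2)nc2ccc(F)cc12` adds a fluorine to the core and a 2-methoxyphenyl on the nitrogen. In this assay compound 2 also gives only a limit, > 50000 nM. Compound 3 `Fc1cccc(-c2nc(Nc3cccc(Cl)c3)c3cc(F)ccc3n2)c1` carries 3-chlorophenyl instead. In this assay compound 3 again gives only a limit, > 50000 nM. Compound 2 therefore stands at the limit, like every value shown; the step that the two limits leave unreadable from compound 2 to compound 3 cannot be read, because of the limit of > 50000 nM in this assay, at which 3 of the 3 values shown sit.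

Compound 4 `Fc1cccc(-c2nc(Nc3ccc(Br)cc3)c3cc(F)ccc3n2)c1` is not yet measured. Relative to compound 2 it changes by 4-bromophenyl in place of 2-methoxyphenyl on a nitrogen on an aromatic ring. Within the data shown here, the only step that bears on this change is the one from compound 2 to compound 3, which is unreadable; no measured step shows a direction.

Compound 4 is expected in this assay at about 60000 nM, within 20000 nM to 200000 nM, most likely reported again only as a limit. The step that the limit leaves unreadable from compound 2 to compound 4 is thus expected to be none beyond the scatter.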

Compound 4, half-maximal inhibitory concentration: > 50000 nM
Compound 4 was reported as a limit; the forecaster's own chance of this, stated with the estimate: 85%; the middle value lies beyond the limit too.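

No new step can be read from compound 4 to compound 2 or compound 3, because all three stand only as limits: the limit of > 50000 nM in this assay, at which 4 of the 4 values shown sit.

The compounds shown leave open whether any group on the nitrogen gives a measurable value in this assay.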